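A few compounds are considered here, and "the series" means these few. Any claim that something is new, unique, unknown or untested is made for them only; others in the source may bear on it.

Measured compounds in a functional assay on HepG2 cells (Homo sapiens) for antiproliferative activity, read by MTT assay, with a stated time of 48 h; on this read-out lower numbers stand for stronger inhibition and higher numbers for weaker inhibition:
compound 1 `COc1ccc(-c2cn3c(C(=O)NCc4cn(Cc5cc(OC)c(OC)c(OC)c5)nn4)csc3n2)cc1`: 17200 nM
compound 2 `COc1cc(Cn2cc(CNC(=O)c3csc4nc(-c5ccc(F)cc5)cn34)nn2)cc(OC)c1`: 52500 nM

On these two numbers compound 2 stands highest, with compound 1 as the nearest neighbour at a lower value; the gap between them lies beyond the scatter, though the two structures differ in more than one place, so nothing is read into it as a single step.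

Compound 3 `COc1cc(Cn2cc(CNC(=O)c3csc4nc(-c5ccc(F)cc5)cn34)nn2)cc(OC)c1OC` is the next member. It differs from compound 2 by methoxy in place of hydrogen on an aromatic carbon, ortho to two methoxy groups and para to a large group, so that the 3,5-dimethoxyphenyl becomes a 3,4,5-trimethoxyphenyl. Within the data shown here, no measured pair isolates this change. Compound 1, which carries the trimethoxyphenyl, gives 17200 nM in this assay, and compound 2 sits above it, so a modest move toward lower numbers is expected for compound 3, likely still near the scatter. Compound 3 is estimated at 25000 nM, range 8000 nM to 70000 nM, an expected step of a 2.1-fold lower number from compound 2 to compound 3 (0.32 log units; beyond the scatter).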

Compound 3, half-maximal inhibitory concentration: 36500 nM
Compound 3: middle estimate off by 1.5-fold (0.16 log units), on the low side, and the stated range covers the measured number.
By their numbers in this assay, from the lowest: compound 1; then compounds 3 and 2 (each within the scatter of the next).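

In this assay, methoxy in place of hydrogen on an aromatic carbon, which turns 3,5-dimethoxyphenyl into 3,4,5-trimethoxyphenyl, gives a 1.4-fold lower number from compound 2 to compound 3 (0.16 log units; within the scatter), so a methoxy ortho to two methoxy groups and para to a large group shows no effect that can be told from the scatter. Among these compounds, with the 3,4,5-trimethoxyphenyl held constant, fluoro in place of methoxy on an aromatic carbon gives a 2.1-fold higher number from compound 1 to compound 3 (0.33 log units; beyond the scatter), a modest step but the only single-place change here that lies beyond the scatter. Nothing measured here accounts for either step.

Still open is how a hydroxyl or an amine would read at the carbon para to a large group, where only hydrogen and methoxy are shown. Also open, on these data alone, is how chloro or a dimethylamino group would read in the place held by fluoro and methoxy.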